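A few compounds are considered here, and "the series" means these few. Any claim that something is new, unique, unknown or untested is made for them only; others in the source may bear on it.

Measured in an assay on HEK293-A cells for activation of Nicotinamide phosphoribosyltransferase (Homo sapiens), tested at 10 uM; a higher number here means a stronger effect of the compound at the concentration tested, a lower number a weaker effect:

compound 1 `CC(C)(C)OC(=O)N1CCC(c2nc3ccc(NC(=O)NCc4ccncc4)cn3n2)CC1` gives 69%
compound 2 `Cc1ccc(C(=O)n2ccc3cc(NC(=O)NCc4ccncc4)ccc32)cc1` gives 89%
compound 3 `O=C(NCc1cn[nH]c1)Nc1ccc2nc(-c3ccccc3)nn2c1` gives 174%

Compound 3 stands highest of the three numbers in this assay; compound 2 is nearest, lower by a gap beyond the scatter, and compound 1 is furthest, also beyond the scatter. For the measured compounds named here, neither gap is a single-point change, so no measured step exists for this series.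

Compound 4 `O=C(NCc1cnco1)Nc1ccc2nc(-c3ccccc3)nn2c1` differs from compound 3 in one place: 1,3-oxazol-5-yl in place of 1H-pyrazol-4-yl on a saturated chain carbon bound to an amide-type nitrogen. Going by the values given here, no measured pair shows this change, so the expectation rests on compound 3 alone, and a modest fall is expected, a number 39 percentage points lower from compound 3 to compound 4 (beyond the scatter), a step that may or may not exceed the scatter. Compound 4 is estimated at 135%, with a range from 80% to 185%.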

Compound 4, a percentage reported as activity, at one concentration (the size of the read-out at that concentration, not a potency): 138%
The estimate for compound 4 lay 3 percentage points below the measured number, and the stated range covers the measured number.
By their numbers in this assay, from the lowest: compound 1; then compound 2; then compound 4; then compound 3.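

In this assay, for the compounds shown here, the first single-place comparison, (1H-pyrazol-4-yl)methyl to (1,3-oxazol-5-yl)methyl gives a number 36 percentage points lower from compound 3 to compound 4 (beyond the scatter), so the ring on this saturated chain carbon bears on the read-out. The change removes the hydrogen-bond donor and adds an acceptor, but this one pair cannot separate those counts from the change of ring atoms. Nothing available explains the step. Open, from the compounds shown here alone, is whether 1H-imidazol-4-yl or a longer chain at this place would match compound 3. Going by these compounds, whether the step carries over to the cores of compound 1 and compound 2 also remains open.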